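The source may hold more compounds than are shown below. What is called first, only, known or untested is meant among the compounds shown, and "the series" means these compounds.

Compound 1, `O=C1O/C(=C\Cn2cc(-c3ccc(Br)cc3)nn2)C(OCc2ccccc2)=C1OCc1ccccc1`: in an ADME assay on HFF cells (Homo sapiens) for cytotoxicity, read by MTT assay, with a stated time of 72 h (a higher number here means a weaker inhibitor, a lower number a stronger inhibitor), compound 1 gives > 100000 nM.
Compound 2, `O=C1O[C@H]([C@@H](O)Cn2cc(-c3ccc(Br)cc3)nn2)C(OCc2ccccc2)=C1OCc1ccccc1`: compound 2 gives 5100 nM.
Compound 3, `O=C1O[C@H]([C@@H](O)Cn2cc(-c3cc(C(F)(F)F)cc(C(F)(F)F)c3)nn2)C(OCc2ccccc2)=C1OCc1ccccc1`: compound 3 gives 80700 nM.

The value for compound 1 is not a number but a limit of this assay, (the limit of > 100000 nM in this assay, at which 1 of the 3 values shown sits). So compound 1 stands at the weak end of what this assay can report, with no exact figure. Among the measured compounds shown here, compound 2 and compound 3, which carry a hydroxyl in place of the double bond, each give a measurable number, and the two numbers differ from one another, though no step between them is described here.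

Compound 4, `Cc1ccc(-c2cn(C/C=C3\OC(=O)C(OCc4ccccc4)=C3OCc3ccccc3)nn2)cc1`, differs from compound 1 in one place: methyl in place of bromo on an aromatic carbon. For the measured compounds named here, no measured pair shows what this exchange does in this assay. Given that compound 1 sits at the limit, the expectation is that compound 4 stays at or near that same weak end, so the step that the limit leaves unreadable from compound 1 to compound 4 is expected to be none beyond the scatter. The estimate for compound 4 is 150000 nM, with a range from 50000 nM to 500000 nM.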

Compound 4, half-maximal inhibitory concentration: > 100000 nM
Compound 4: only a limit was reported (the forecaster's own chance of this, stated with the estimate: 70%); the middle value does not contradict the limit.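

Compound 1 and compound 4 both give only a limit in this assay, so no step can be read for methyl in place of bromo: the limit of > 100000 nM in this assay, at which 2 of the 4 values shown sit.
The compounds shown leave open whether this exchange shifts the value at all where a measurable number is obtained.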